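From trifluoromethyl to hydrogen on the aromatic ring

A few compounds are considered here, and "the series" means these few. Any claim that something is new, unique, unknown or untested is made for them only; others in the source may bear on it.

Among the compounds with values here, in a functional assay on HeLa cells (Homo sapiens) for antiproliferative activity, read by sulforhodamine B assay, with a stated time of 72 h (on this read-out lower numbers stand for stronger inhibition and higher numbers for weaker inhibition), compound 2 (`FC(F)(F)c1ccc(NC(=S)N/N=C/c2ccc3ccccc3n2)cc1`) gives 59100 nM, the only actual number so far. Compound 1 (`S=C(N/N=C/c1ccc2ccccc2n1)Nc1ccc(Cl)cc1`) gives > 100000 nM, which is a limit of the assay. Compound 3 (`S=C(N/N=C/c1ccc2ccccc2n1)Nc1ccccc1`) differs from compound 2 by hydrogen in place of trifluoromethyl on an aromatic carbon. Within the data shown here, the one measured step at this place is an at least 1.6-fold lower number from compound 1 to compound 2 (0.22 log units; that floor lies within the scatter), with trifluoromethyl in place of chloro. With so small a floor, no step beyond the scatter is expected in this assay. The estimated step is a 1.0-fold higher number from compound 2 to compound 3 (0.01 log units; within the scatter). Compound 3 is expected at 60000 nM, within an estimated range of 15000 nM to 150000 nM.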

Compound 3, half-maximal inhibitory concentration: 27400 nM
Compound 3: the middle estimate sits 2.2-fold (0.34 log units) above what was measured; low and high end bracket the measured number.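

In this assay, this position now shows a step beyond the scatter, and it comes from removing the group rather than exchanging one for another: a 2.2-fold lower number from compound 2 to compound 3 (0.33 log units; beyond the scatter). Hydrogen also compares favourably with chloro, with an at least 3.6-fold lower number from compound 1 to compound 3 (0.56 log units; beyond the scatter), so the unsubstituted ring gives the strongest inhibition of the three. Compound 1 stands at a limit of the assay, which makes that second step a floor only: the limit of > 100000 nM in this assay, at which 1 of the 3 values shown sits.

From the compounds shown here alone, whether an amine, a methoxy group or a carboxylic acid at this place would give a lower number than hydrogen stays open. So does whether the same order would hold on a different core.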